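Swapping a Pyridine for a Phenyl on a Triazole Arm

The source may report more compounds than this note shows. Statements on the series, on what has been measured and on what is new or still open speak of the compounds shown alone.

Compound 1 `C=C1C[C@]23C[C@@]1(O)CC[C@H]2c1ccc(O)c(C)c1[C@@H]3Cn1cc(-c2ccccn2)nn1` is the starting point. In a functional assay on SMMC-7721 cells (Homo sapiens) for cytotoxicity, read by MTT assay, with a stated time of 4 days (on this read-out higher numbers stand for weaker inhibition and lower numbers for stronger inhibition), compound 1 gives > 20000 nM, which is a limit of the assay rather than a measured number, so its standing cannot be placed more precisely than that. Compound 2 `C=C1C[C@]23C[C@@]1(O)CC[C@H]2c1ccc(OS(=O)(=O)c2ccc(C)cc2)c(C)c1[C@@H]3Cn1cc(-c2ccc(Cl)cc2)nn1` gives > 20000 nM in this assay, again only a limit. Compound 3 `C=C1C[C@]23C[C@@]1(O)CC[C@H]2c1ccc(OS(=O)(=O)c2ccc(C)cc2)c(C)c1[C@@H]3Cn1cc(-c2ccc(OC)cc2)nn1` gives > 20000 nM in this assay, also a limit. For the measured compounds named here, the one step between measured compounds, a step that the two limits leave unreadable from compound 2 to compound 3, therefore cannot be read in either direction. The common thread is the limit of > 20000 nM in this assay, at which 3 of the 3 values shown sit, meaning no compound so far has shown measurable inhibition.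

Compound 4 `C=C1C[C@]23C[C@@]1(O)CC[C@H]2c1ccc(O)c(C)c1[C@@H]3Cn1cc(-c2ccccc2)nn1` differs from compound 1 in one place: phenyl in place of pyridin-2-yl on an aromatic carbon. Going by the values given here, no measured step involves this change, so nothing in the data says whether it helps or hurts; the only available evidence, (the limit of > 20000 nM in this assay, at which 3 of the 3 values shown sit), points to weak activity across the set. Compound 4 is therefore expected to sit near or beyond the same limit, with an estimated value of 25000 nM (range 8000 nM to 80000 nM), and the expected step that the limit leaves unreadable from compound 1 to compound 4 is essentially none.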

Compound 4, half-maximal inhibitory concentration: > 20000 nM
Compound 4: no number, only a limit; the forecaster's own chance of this, stated with the estimate: 85%; the middle value does not contradict the limit.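

Compound 4 gives > 20000 nM, which is a limit and not a number. For the compounds shown here, compound 1 is also only a limit, so no step from compound 1 to compound 4 can be read. Still open is whether phenyl and pyridin-2-yl differ at all, and whether any compound shown has a measurable effect in this assay: the limit of > 20000 nM in this assay, at which 4 of the 4 values shown sit.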